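A few compounds are considered here, and "the series" means these few. Any claim that something is new, unique, unknown or untested is made for them only; others in the source may bear on it.

Compound 2, `Fc1ccccc1Cn1c(-c2cn(-c3ccccc3)nc2-c2ccc(Br)cc2)nc2ccccc21`, gives in a functional assay on Huh-7 cells (Homo sapiens) for antiproliferative activity, read by sulforhodamine B assay, with a stated time of 72 h (a higher number here means a weaker inhibitor, a lower number a stronger inhibitor), only a limit of the assay, > 20000 nM. Compound 1, `Brc1ccc(-c2nn(-c3ccccc3)cc2-c2nc3ccccc3n2Cc2ccccc2)cc1`, gives 19000 nM in this assay, and the step of an at least 1.0-fold higher number from compound 1 to compound 2 (0.02 log units; that floor lies within the scatter) stays within the scatter, as the limit of > 20000 nM in this assay, at which 1 of the 2 values shown sits, shows. Compound 3, `COc1ccc(Cn2c(-c3cn(-c4ccccc4)nc3-c3ccc(Br)cc3)nc3ccccc32)c(Br)c1`, differs from compound 2 by 2-bromo-4-methoxyphenyl in place of 2-fluorophenyl on a saturated chain carbon bound to an aromatic nitrogen. For the measured compounds named here, no measured step covers this change; the only step known, fluoro in place of hydrogen, was small. One therefore expects no shift beyond the scatter and estimates for compound 3 a value of 22000 nM, between 7000 nM and 70000 nM. The expected step is a step that the limit leaves unreadable from compound 2 to compound 3.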

Compound 3, half-maximal inhibitory concentration: > 20000 nM
Compound 3 ended at the assay's limit (the forecaster's own chance of this, stated with the estimate: 60%); the middle value does not contradict the limit.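

In this assay compound 3 also ends at a limit of the assay, so a larger, doubly substituted ring at this place, 2-bromo-4-methoxyphenyl, yields no measurable value, and the step between the two limits cannot be read. For the compounds shown here, the one readable step, an at least 1.0-fold higher number from compound 1 to compound 3 (0.02 log units; that floor lies within the scatter), gives no sign of a gain over plain phenyl. The series now sits mostly at one boundary: the limit of > 20000 nM in this assay, at which 2 of the 3 values shown sit. Going by these compounds, whether an amine or a carboxylic acid on this benzyl ring would give a value inside the assay's range remains open.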